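Adding an Amino Group to a Weakly Cytotoxic Core

A few compounds are considered here, and "the series" means these few. Any claim that something is new, unique, unknown or untested is made for them only; others in the source may bear on it.

Compound 1 `CCn1cc(-c2nc3ccccc3[nH]2)c(=O)c2cc(F)c(N3CCNCC3)cc21`: > 10000 nM, a limit of the assay.
Compound 2 `CCn1cc(-c2nc3ccccc3[nH]2)c(=O)c2cc(F)c(N3CCNCC3)nc21`: 9100 nM.
Compound 3 `CCn1cc(-c2nc3ccc(N)cc3[nH]2)c(=O)c2cc(F)c(N3CCNCC3)cc21`: > 10000 nM, a limit of the assay.

In a functional assay on K562 cells (Homo sapiens) for cytotoxicity, read by sulforhodamine B assay, with a stated time of 48 h (on this read-out higher numbers stand for weaker inhibition and lower numbers for stronger inhibition), compound 2 is the only one of the three that gives a number; compound 1 and compound 3 sit at the limit of > 10000 nM in this assay, at which 2 of the 3 values shown sit. Compound 3 carries one change against compound 1, (amino in place of hydrogen on an aromatic carbon), and the step that the two limits leave unreadable from compound 1 to compound 3 cannot be read because the limit of > 10000 nM in this assay, at which 2 of the 3 values shown sit, hides both ends. The difference between the core of compound 1 and the core of compound 2 is not broken down here.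

Compound 4 `CCn1cc(-c2nc3ccc(N)cc3[nH]2)c(=O)c2cc(F)c(N3CCNCC3)nc21` is not yet measured. It stands to compound 2 as compound 3 stands to compound 1: the change is amino in place of hydrogen on an aromatic carbon, the same change, since the place is described in identical words. Among the measured compounds shown here, with the only earlier example of this change unreadable, the expectation for compound 4 rests on compound 2 alone, so the expected step of a 1.0-fold lower number from compound 2 to compound 4 (0.00 log units; within the scatter) is close to none. Compound 4 is therefore estimated at 9000 nM, expected between 3000 nM and 30000 nM.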

Compound 4, half-maximal inhibitory concentration: > 10000 nM
Compound 4 ended at the assay's limit; the forecaster's own chance of this, stated with the estimate: 40%; middle value at least 1.1-fold (0.04 log units) from the limit.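

In this assay compound 4 gives > 10000 nM, which is a limit of the assay and not a true number. Swapping hydrogen for amino on the core of compound 2 gives an at least 1.0-fold higher number from compound 2 to compound 4 (0.04 log units; that floor lies within the scatter), so this change brought no stronger inhibition on this core, though the real size of the step may be anywhere from that floor upward. The step on the core of compound 1 cannot be read, so the two steps cannot be compared, and it remains unshown whether amino acts by the same amount on both cores, because both members of that pair and compound 4 end at the same ceiling: the limit of > 10000 nM in this assay, at which 3 of the 4 values shown sit.

The compounds shown leave open whether another group on the same aromatic carbon, such as a carboxylic acid or a longer amine chain, would give a number clear of the limit. Also open, as far as these compounds go, is how far compound 3 and compound 4 actually lie from that limit.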